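A few compounds are considered here, and "the series" means these few. Any claim that something is new, unique, unknown or untested is made for them only; others in the source may bear on it.

Three compounds have been measured in a functional assay on A549 cells (Homo sapiens) for antiproliferative activity, read by MTT assay, with a stated time of 72 h; a lower number here means a stronger inhibitor, a higher number a weaker inhibitor:

compound 1 `O=C(N/N=C/c1ccc(O)cc1)Nc1ccc(Oc2ccnc3[nH]ccc23)c(F)c1`: 3760 nM
compound 2 `COc1ccc(/C=N/NC(=O)Nc2ccc(Oc3ccnc4[nH]ccc34)c(F)c2)cc1`: 3980 nM
compound 3 `O=C(N/N=C/c1ccc(O)cc1)Nc1ccc(Oc2ccnc3[nH]ccc23)cc1`: 1910 nM

Compound 2 differs from compound 1 by methyl in place of hydrogen on an oxygen on an aromatic ring; the step was a 1.1-fold higher number from compound 1 to compound 2 (0.02 log units; within the scatter). Compound 3 differs from compound 1 in its core, by hydrogen in place of fluoro on an aromatic carbon, and that step was a 2.0-fold lower number from compound 1 to compound 3 (0.29 log units; within the scatter). Compound 4 `COc1ccc(/C=N/NC(=O)Nc2ccc(Oc3ccnc4[nH]ccc34)cc2)cc1` has not yet been measured. It differs from compound 3 by methyl in place of hydrogen on an oxygen on an aromatic ring, the same change as that from compound 1 to compound 2, made on the core of compound 3. The expectation rests on the earlier step of a 1.1-fold higher number from compound 1 to compound 2 (0.02 log units; within the scatter), which stayed within the scatter. Compound 4 is therefore expected to give about 2100 nM in this assay. Its value is estimated to fall between 1000 nM and 4300 nM. The step this estimate means is a 1.1-fold higher number from compound 3 to compound 4 (0.04 log units; within the scatter).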

Compound 4, half-maximal inhibitory concentration: 4300 nM
Beside the measured number, compound 4's estimate is 2.0-fold (0.31 log units) below it, and the stated range covers the measured number.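

In this assay, hydroxy to methoxy gave a 2.3-fold higher number from compound 3 to compound 4 (0.35 log units; beyond the scatter), and the two steps for this change do not differ by more than two such steps can scatter: the same change on two cores in this assay, a 1.1-fold higher number (0.02 log units; within the scatter) from compound 1 to compound 2 and a 2.3-fold higher number (0.35 log units; beyond the scatter) from compound 3 to compound 4, 2.1-fold (0.33 log units) apart, within the scatter of two such steps. Hydrogen in place of fluoro gave a 1.1-fold higher number from compound 2 to compound 4 (0.03 log units; within the scatter), and this change likewise shows no resolved difference between its two steps: the same change on two cores in this assay, a 2.0-fold lower number (0.29 log units; within the scatter) from compound 1 to compound 3 and a 1.1-fold higher number (0.03 log units; within the scatter) from compound 2 to compound 4, 2.1-fold (0.33 log units) apart, within the scatter of two such steps. Both changes are therefore compatible with carrying over between these cores, but this does not show that their effects are equal, as one methoxy step lies beyond the scatter and the other within it, and two pairs establish no rule for the series.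

The compounds shown leave open how a longer chain on that oxygen, or an amine or a carboxylic acid in place of the hydroxy, would read in this assay.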